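Swapping the thiophene substituent in a sulfonylurea

This account rests on a few compounds, and the source may have more. Where it says the series, first, only, none or still open, it means among the compounds named here.

Compound 1, with the structure `O=C(Nc1ccc(Cl)cc1)NS(=O)(=O)c1ccc(Cl)s1`, is one of two compounds tested in a functional assay on the whole organism (6C3HED cells, Mus musculus) for inhibition, at a dose of 300 mg/kg by the oral route (on this read-out lower numbers stand for less inhibition and higher numbers for more inhibition at the one dose given (going by the name of the read-out)), and there compound 1 gives 89%, the higher of the two numbers. Its companion is compound 2, with the structure `Cc1ccc(S(=O)(=O)NC(=O)Nc2ccc(Cl)c(Cl)c2)s1`, which in this assay gives 61%. The gap between compound 1 and compound 2 is larger than the usual scatter of repeated measurements, so compound 1 stands clearly on top of this small set, although compound 2 differs from it in more than one place, so no single change can be read off from the pair.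

The new compound is compound 3, with the structure `Cc1ccsc1S(=O)(=O)NC(=O)Nc1ccc(Cl)cc1`. It differs from compound 1 in one place: 3-methylthiophen-2-yl in place of 5-chlorothiophen-2-yl on a sulfonyl sulfur. Going by the values given here, no measured pair shows this change alone, so the size of its effect is unknown. Compound 3 is expected to show somewhat less inhibition than compound 1, a step of a number 17 percentage points lower from compound 1 to compound 3 (beyond the scatter) in this assay, at the edge of the scatter. The estimate for compound 3 is 72%, within a range from 45% to 92%.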

Compound 3, a percentage reported as inhibition, in the whole organism at one dose (the size of the read-out at that dose, not a potency): 62%
Estimate against measurement, compound 3: 10 percentage points above; the measured number falls inside the stated range.
By their numbers in this assay, from the lowest: compounds 2 and 3 (each within the scatter of the next); then compound 1.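

Going by these compounds alone, compound 1 and compound 3 differ only in the group on the sulfonyl sulfur, so this pair isolates that one change for the first time: in this assay, 3-methylthiophen-2-yl in place of 5-chlorothiophen-2-yl gives a number 27 percentage points lower from compound 1 to compound 3 (beyond the scatter). The group at this position therefore matters to the read-out, yet the change does not abolish inhibition, as compound 3 still gives 62%. Nothing available explains why the number falls with this change.

The two group names show that the swap alters both the substituent, methyl for chlorine, and its numbered place on the thiophene, and this single pair cannot separate those two changes. As far as these compounds go, it also remains open how a bromine atom, a methoxy group or a carboxylic acid on the thiophene would compare with the chlorine of compound 1, and since the read-out comes from one oral dose, it gives the size of the inhibition at that dose rather than a potency.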